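This account rests on a few compounds, and the source may have more. Where it says the series, first, only, none or still open, it means among the compounds named here.

Measured so far in a functional assay on HepG2 cells (Homo sapiens) for antiproliferative activity, read by CCK-8 assay, with a stated time of 72 h; on this read-out higher numbers stand for weaker inhibition and lower numbers for stronger inhibition (both entries are limits of the assay, not numbers):
- compound 1 `Nc1ccccc1NC(=O)c1ccc(COc2ccc([N+](=O)[O-])cc2)cc1` gives > 32000 nM
- compound 2 `Nc1ccccc1NC(=O)/C=C/c1ccc(COc2ccccc2)cc1` gives > 32000 nM

Compound 2 sits at the limit of > 32000 nM in this assay, at which 2 of the 2 values shown sit, so its position is a limit and not a number. Compound 3 `O=C(/C=C/c1ccc(COc2ccccc2)cc1)NO` carries hydroxy in place of 2-aminophenyl on an amide-type nitrogen. Within the data shown here, no measured step sizes this change. A sizeable move toward stronger inhibition is expected in this assay, and the expected at least 10-fold lower number from compound 2 to compound 3 (1.02 log units; beyond the scatter) remains loosely bounded. For compound 3 the estimate is 3000 nM, with an expected range from 500 nM to 20000 nM.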

Compound 3, half-maximal inhibitory concentration: 8400 nM
Compound 3: middle estimate off by 2.8-fold (0.45 log units), on the low side; the range from low to high includes it.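

In this assay, among these compounds, hydroxy in place of 2-aminophenyl on the amide-type nitrogen gives the first value that is a number, with compound 3 at 8400 nM. This position therefore responds to the change, which gives an at least 3.8-fold lower number from compound 2 to compound 3 (0.58 log units; beyond the scatter). The value of compound 2 is a limit, so the step has only a lower bound: the limit of > 32000 nM in this assay, at which 2 of the 3 values shown sit.

Still open, as far as these compounds go, is whether a methoxy group on this nitrogen would keep the gain. Also open, from the compounds shown here alone, is whether hydroxy would give a similar step on the core of compound 1.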